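Replacing ethoxy with cyclohexylamino in compound 3

A few compounds are considered here, and "the series" means these few. Any claim that something is new, unique, unknown or untested is made for them only; others in the source may bear on it.

- compound 1 `C=CC(=O)Nc1nc(-c2ccc3ccccc3c2)cs1`: 12500 nM
- compound 2 `C=CC(=O)Nc1nc(-c2ccccc2)c(C)s1`: 22000 nM
- compound 3 `C=CC(=O)N(CC(=O)OCC)c1nc(-c2ccccc2)cs1`: 19000 nM

All three compounds were tested in a functional assay on HT-29 cells (Homo sapiens) for antiproliferative activity, read by MTT assay, with a stated time of 72 h; on this read-out lower numbers stand for stronger inhibition and higher numbers for weaker inhibition. There, compound 3 gives 19000 nM. That number lies within the usual scatter of both other measurements, so the data do not place compound 3 clearly ahead of or behind either compound.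

The next compound is compound 4 `C=CC(=O)N(CC(=O)NC1CCCCC1)c1nc(-c2ccccc2)cs1`. It has cyclohexylamino in place of ethoxy on a carbonyl carbon. The shared core stays the same.

Going by the values given here, no two measured compounds differ in just one place, so the data offer no direct guide to this change. The three values sit close together, which gives no reason to expect a large jump. In this assay, a shift toward a slightly lower number is expected, but none beyond the scatter. The expected change is a 1.4-fold lower number from compound 3 to compound 4 (0.13 log units; within the scatter). For compound 4, the estimated value is 14000 nM, with an expected range from 5000 nM to 40000 nM.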

Compound 4, half-maximal inhibitory concentration: > 30000 nM
Compound 4 ended at the assay's limit (the forecaster's own chance of this, stated with the estimate: 10%); middle value at least 2.1-fold (0.33 log units) from the limit.
By their numbers in this assay, from the lowest: compounds 1, 3 and 2 (each within the scatter of the next). At a limit, above all of these: compound 4.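

Going by these compounds alone, this is the first step in this assay that changes only one place, and cyclohexylamino in place of ethoxy on a carbonyl carbon gives an at least 1.5-fold higher number from compound 3 to compound 4 (0.19 log units; that floor lies within the scatter). Compound 4 gives > 30000 nM, which is a limit of the assay and not a number. The swap therefore brings no sign of stronger inhibition at this position, but how much weaker compound 4 may be cannot be read because the measurement stops at the limit: the limit of > 30000 nM in this assay, at which 1 of the 4 values shown sits.

The compounds shown leave open whether the ring or the nitrogen of the entering group matters more at this position. An open-chain amine such as ethylamino, or a carboxylic acid, on the same carbonyl carbon would help to separate these two features.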